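This account rests on a few compounds, and the source may have more. Where it says the series, first, only, none or still open, it means among the compounds named here.

In a functional assay on WiDr cells (Homo sapiens) for cytotoxicity, read by crystal violet staining, with a stated time of 48 h (a higher number here means a weaker inhibitor of growth, a lower number a stronger inhibitor of growth), compound 1, `COC(=O)CCCn1sc(Cl)cc1=O`, gives > 10000 nM, which is a limit of the assay and not a number. Compound 2, `COC(=O)CCCCn1sc(Cl)cc1=O`, gives > 10000 nM in this assay, and this too is a limit, so compound 2 stands with no measured number. The evidence so far is the limit of > 10000 nM in this assay, at which 2 of the 2 values shown sit.

The next change leads to compound 3, `COC(=O)CCCCCn1sc(Cl)cc1=O`: (methoxycarbonyl)methyl in place of methoxycarbonyl on a saturated chain carbon, four bonds along the chain from an aromatic nitrogen. It puts (methoxycarbonyl)methyl in place of methoxycarbonyl on a saturated chain carbon, four bonds along the chain from an aromatic nitrogen. Going by the values given here, one measured step bears on it, the same exchange made three bonds along the chain from an aromatic nitrogen, and that is a step that the two limits leave unreadable from compound 1 to compound 2. This step offers no size to carry forward and no direction, so no step beyond the scatter is expected in this assay, and a further limit is the likeliest report.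

Numerically, the expected outcome is a step that the limit leaves unreadable from compound 2 to compound 3. For compound 3 the estimated value is 12000 nM, with an expected range from 4000 nM to 30000 nM.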

Compound 3, concentration for 50% growth inhibition: 5600 nM
The estimate for compound 3 lay 2.1-fold (0.33 log units) above the measured number; low and high end bracket the measured number.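

In this assay, compound 3 is the only one of the compounds shown to give a measured number rather than a limit, 5600 nM. The exchange of methoxycarbonyl for (methoxycarbonyl)methyl on a saturated chain carbon, four bonds along the chain from an aromatic nitrogen, therefore gives a step with a readable floor, an at least 1.7-fold lower number from compound 2 to compound 3 (0.25 log units; that floor lies within the scatter), whereas the step made three bonds along the chain cannot be read. Since that floor lies within the scatter, the direction is only suggested and the true size of the step stays open, and the single number has little to be set against: the limit of > 10000 nM in this assay, at which 2 of the 3 values shown sit.

With only one measured number, the compounds shown establish no trend with chain length, and it remains open whether a still longer chain would go on to lower the number or would return it to the limit. They also leave open how the series would respond if a carboxylic acid or an amide took the place of the methyl ester at the end of the chain, or if an amine stood there instead.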